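Oxadiazole-quinoline series: carbamate in place of the urea

The source may report more compounds than this note shows. Statements on the series, on what has been measured and on what is new or still open speak of the compounds shown alone.

Two compounds of the series have numbers in a functional assay on Shh Light II cells (Mus musculus) for inhibition, read by a luciferase reporter (a lower number here means a stronger inhibitor, a higher number a weaker inhibitor), so far. Compound 1 `O=C(Nc1ccccc1Cl)N1CCN(c2nc(-c3ccc4ccccc4n3)no2)CC1` carries a urea on a piperazine ring; in this assay compound 1 gives 140 nM. Compound 2 `Cc1noc(C)c1NC(=O)N1CCC(c2nc(-c3ccc4ccccc4n3)no2)CC1` carries a urea on a piperidine ring and a different aromatic group on the urea nitrogen; in this assay compound 2 gives 3000 nM. Compound 2 thus stands at the higher of the two numbers, and the gap to compound 1 lies beyond the usual scatter. The two compounds differ in more than one place, so the gap cannot be assigned to a single change.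

Compound 3 `O=C(OC1CCCCC1)N1CCC(c2nc(-c3ccc4ccccc4n3)no2)CC1` keeps the piperidine core of compound 2 and changes the group on the carbonyl carbon: cyclohexyloxy in place of (3,5-dimethyl-1,2-oxazol-4-yl)amino on a carbonyl carbon. For the measured compounds named here, no step of this kind has been measured, and compound 1 differs from compound 3 in more than one place, so there is no direct reference for the change. A step within the scatter, or a small move towards a lower number, is expected. In this assay compound 3 is estimated at 2000 nM, within a range of 500 nM to 8000 nM, which is expected to mean a step of a 1.5-fold lower number from compound 2 to compound 3 (0.18 log units; within the scatter).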

Compound 3, half-maximal inhibitory concentration: 580 nM
The estimate for compound 3 lay 3.4-fold (0.54 log units) above the measured number; measured number inside the range.
By their numbers in this assay, from the lowest: compound 1; then compound 3; then compound 2.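

In this assay cyclohexyloxy in place of (3,5-dimethyl-1,2-oxazol-4-yl)amino on a carbonyl carbon gives a 5.2-fold lower number from compound 2 to compound 3 (0.71 log units; beyond the scatter) and so shows that this position does not depend on a urea: a carbamate with a non-aromatic carbon ring, whose entering group has 0 hydrogen-bond donors, is tolerated on this core and gives the lower number of the pair. The step changes the linking atom and the ring together, so it cannot show which of the two accounts for the gap. Nothing measured on these compounds bears on the reason for the step.

Open, as far as these compounds go, is whether cyclohexylamino on the same carbonyl carbon, which would keep the ring and bring back the nitrogen, would read like compound 3 or like compound 2, and whether phenoxy or a short chain such as ethoxy would hold the lower number. Also open, from the compounds shown here alone, is whether cyclohexyloxy would give a comparable step on the piperazine ring of compound 1, since that compound differs from compound 3 in more than one place.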